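A fluoro step on a compound at the limit

The source may report more compounds than this note shows. Statements on the series, on what has been measured and on what is new or still open speak of the compounds shown alone.

Compound 1 `CCOC(=O)c1c(-c2cccc(OC)c2)[nH]c2cc(OC)ccc2c1=O`: > 21500 nM (a limit)
Compound 2 `CCOC(=O)c1c(-c2cccc(C(C)=O)c2)[nH]c2cc(OC)ccc2c1=O`: > 21500 nM (a limit)

In an ADME assay on HepG2 cells (Homo sapiens) for cytotoxicity, read by luminescence, with a stated time of 72 h (on this read-out higher numbers stand for an effect only at larger amounts of compound and lower numbers for an effect already at smaller amounts), compound 1 gives > 21500 nM as a limit and not a number. Compound 2 gives > 21500 nM as a limit too. The data show the limit of > 21500 nM in this assay, at which 2 of the 2 values shown sit, and nothing more. For the measured compounds named here, the one measured step is a step that the two limits leave unreadable from compound 1 to compound 2 and so offers no size to carry over. Compound 3 `CCOC(=O)c1c(-c2cccc(OC)c2)[nH]c2cc(OC)c(F)cc2c1=O` has fluoro in place of hydrogen on an aromatic carbon of the core of compound 1 with fluoro in place of hydrogen on an aromatic carbon as the counted difference. With compound 1 at its limit of > 21500 nM no step beyond the scatter is expected in this assay for compound 3. The expected change is a step that the limit leaves unreadable from compound 1 to compound 3 as an estimate only. The estimated value for compound 3 is 30000 nM with an expected range from 12000 nM to 60000 nM.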

Compound 3, half-maximal effective concentration: > 21500 nM
Compound 3: no number, only a limit; the forecaster's own chance of this, stated with the estimate: 80%; the middle value is on the limit's open side.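

No step can be read from compound 1 to compound 3, because each gives only a limit and not a number: the limit of > 21500 nM in this assay, at which 3 of the 3 values shown sit.

As far as these compounds go, whether fluoro in place of hydrogen changes the read-out in this assay stays open, as does any difference among the three compounds.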